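The compounds below may be only part of what the source reports. "The series", "measured", "known", "first", "only" and "open" are said of these compounds alone.

Measured so far in a functional assay on PA-1 cells (Homo sapiens) for cytotoxicity, read by MTT assay, with stated times of 6 h and 48 h; on this read-out lower numbers stand for stronger inhibition and higher numbers for weaker inhibition:

Compound 1, `Cn1c(/C=C/C(=O)c2ccccc2)cc(Br)c1Br`: in this assay compound 1 gives >= 100000 nM, which is a limit of the assay and not a number.
Compound 2, `Cn1c(/C=C/C(=O)c2ccc[nH]2)cc(Br)c1Br`: in this assay compound 2 gives 730 nM.
Compound 3, `O=C(/C=C/c1cc(Br)c(Br)[nH]1)c1ccccc1`: in this assay compound 3 gives >= 100000 nM, again a limit and not a number.

Going by the values given here, compound 2 carries the only number in the set; the two other values sit at the limit of >= 100000 nM in this assay, at which 2 of the 3 values shown sit. The cores of compound 1 and compound 2 differ by 1H-pyrrol-2-yl in place of phenyl on a carbonyl carbon, and this change gives an at least 130-fold lower number from compound 1 to compound 2 (2.13 log units; beyond the scatter).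

The change from compound 1 to compound 3 is hydrogen in place of methyl on an aromatic nitrogen; because both values sit at the limit of >= 100000 nM in this assay, at which 2 of the 3 values shown sit, the step reads as a step that the two limits leave unreadable from compound 1 to compound 3.

Compound 4, `O=C(/C=C/c1cc(Br)c(Br)[nH]1)c1ccc[nH]1`, is not yet measured in this assay. It differs from compound 2 by hydrogen in place of methyl on an aromatic nitrogen. This is the same kind of change as that from compound 1 to compound 3, but the surroundings are described differently: in compound 1 the ring atom next to the nitrogen bears a large group, in compound 2 it bears a group of 9 heavy atoms.

The one earlier example of this change gives no readable size, so the expectation for compound 4 rests only on the value of compound 2, 730 nM, and on the absence of any shown step for the change. Compound 4 is expected to give a step of about a 2.1-fold higher number from compound 2 to compound 4 (0.31 log units; beyond the scatter), a number close to that of compound 2. The estimate for compound 4 is 1500 nM, with a range from 300 nM to 10000 nM.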

Compound 4, half-maximal inhibitory concentration: 500 nM
The estimate for compound 4 lay 3.0-fold (0.48 log units) above the measured number, within the range that was stated.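

In this assay, hydrogen in place of methyl on an aromatic nitrogen, on the core that carries 1H-pyrrol-2-yl on the carbonyl carbon, gives a 1.5-fold lower number from compound 2 to compound 4 (0.16 log units; within the scatter), so on this core the change makes no difference that can be told from the scatter. The same change on the core that carries phenyl on the carbonyl carbon cannot be read, because compound 1 and compound 3 both sit at a limit and not at a number: the limit of >= 100000 nM in this assay, at which 2 of the 4 values shown sit. Going by these compounds alone, the series therefore holds one readable example of this change, and that example shows only that the methyl group on this nitrogen can be exchanged for hydrogen with 1H-pyrrol-2-yl in place; it does not show that the change behaves alike on the phenyl core, where any shift hidden behind the limits stays unknown.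

The compounds shown leave open whether a group larger than methyl on that aromatic nitrogen, such as ethyl or a longer chain, or a chain ending in an amine or a carboxylic acid, would give values like those of compound 2 and compound 4. They also leave open what chloro or hydrogen in place of either bromo group would do on the core of compound 4.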